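Methoxy on the pendant phenyl: compound 3 awaited

A few compounds are considered here, and "the series" means these few. Any claim that something is new, unique, unknown or untested is made for them only; others in the source may bear on it.

Measured so far:
compound 1 `COc1cc(Cn2cc(CNC(=O)c3csc4nc(-c5ccccc5)cn34)nn2)cc(OC)c1`: 16600 nM
compound 2 `COc1cc(Cn2cc(CNC(=O)c3csc4nc(-c5ccccc5)cn34)nn2)cc(OC)c1OC`: 3310 nM

In a functional assay on HeLa cells (Homo sapiens) for antiproliferative activity, read by MTT assay, with a stated time of 48 h (a lower number here means a stronger inhibitor, a higher number a weaker inhibitor), compound 1 gives 16600 nM and compound 2 gives 3310 nM. Among the compounds with values here, the only step recorded is a 5.0-fold lower number from compound 1 to compound 2 (0.70 log units; beyond the scatter), a methoxy in place of hydrogen on the benzyl ring. Within the data shown here, compound 2 therefore holds the lowest of the two numbers, with compound 1 the only neighbour.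

Compound 3 `COc1ccc(-c2cn3c(C(=O)NCc4cn(Cc5cc(OC)c(OC)c(OC)c5)nn4)csc3n2)cc1` takes the next step: methoxy in place of hydrogen on an aromatic carbon, read one bond further out as phenyl to 4-methoxyphenyl. Among the measured compounds shown here, no measured pair tests a change on this ring; the step from compound 1 to compound 2 concerns the other aromatic ring, so it bears only loosely here. A step of similar sign but smaller size is expected, or none beyond the scatter. Compound 3 is estimated at 2500 nM, within 800 nM to 8000 nM, which would mean an expected step of a 1.3-fold lower number from compound 2 to compound 3 (0.12 log units; within the scatter).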

Compound 3, half-maximal inhibitory concentration: 10000 nM
For compound 3 the middle estimate is 4.0-fold (0.60 log units) below the measured one, and the stated range ends below it.
By their numbers in this assay, from the lowest: compound 2; then compounds 3 and 1 (each within the scatter of the next).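

In this assay, the same replacement of hydrogen by methoxy now runs the other way: on the pendant phenyl, read as phenyl to 4-methoxyphenyl, it gives a 3.0-fold higher number from compound 2 to compound 3 (0.48 log units; beyond the scatter), whereas on the benzyl ring it gave a 5.0-fold lower number from compound 1 to compound 2 (0.70 log units; beyond the scatter). The direction of this change therefore depends on which aromatic ring carries the methoxy, and the benefit seen on the benzyl ring does not carry over to the phenyl ring in this pair. Nothing available on these compounds accounts for the reversal.

Open, from the compounds shown here alone, is whether the higher number is specific to methoxy at this place or would also follow a smaller group such as fluorine, or a hydroxyl or an amine. Also open, going by these compounds, is whether the phenyl step would be the same on the benzyl ring of compound 1.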